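The source may hold more compounds than are shown below. What is called first, only, known or untested is meant among the compounds shown, and "the series" means these compounds.

Measured in a functional assay on NCI-H460 cells (Homo sapiens) for cytotoxicity, read by MTT assay, with a stated time of 72 h (on this read-out higher numbers stand for weaker inhibition and lower numbers for stronger inhibition), so far:
- Compound 1 `CCN(CC)Cc1ccc2nc(NC(=O)N/N=C/c3cn(Cc4ccc(Cl)cc4Cl)c4ccccc34)sc2c1` gives 1080 nM
- Compound 2 `CCN(CC)Cc1ccc2nc(NC(=O)N/N=C/c3cn(Cc4cccc(Cl)c4)c4ccccc34)sc2c1` gives 220 nM
- Compound 3 `CCN(CC)Cc1ccc2nc(NC(=O)N/N=C/c3c[nH]c4ccccc34)sc2c1` gives 3140 nM

Compound 3 stands at 3140 nM as the highest number of the three, which makes it the weakest inhibitor of this small set. It is also the only one with hydrogen on the aromatic nitrogen. Compound 4 `CCN(CC)Cc1ccc2nc(NC(=O)N/N=C/c3cn(Cc4ccccc4)c4ccccc34)sc2c1` has not been measured yet. It differs from compound 3 in one place, with benzyl in place of hydrogen on that aromatic nitrogen (benzyl in place of hydrogen on an aromatic nitrogen).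

Going by the values given here, two measured steps concern this same nitrogen, though they run in the opposite direction. Removing 2,4-dichlorobenzyl gives a 2.9-fold higher number from compound 1 to compound 3 (0.46 log units; beyond the scatter) as a modest step, and removing 3-chlorobenzyl gives a 14-fold higher number from compound 2 to compound 3 (1.15 log units; beyond the scatter) as a large one. Both groups therefore go with lower numbers than hydrogen, but the size of the gain varies, since a 4.9-fold lower number from compound 1 to compound 2 (0.69 log units; beyond the scatter) separates the two chlorinated compounds. No benzyl without chlorine has been tested, so neither step transfers directly.

A lower number is expected, with a step size probably falling between those two. The expected change is a 6.3-fold lower number from compound 3 to compound 4 (0.80 log units; beyond the scatter) in this assay on this reasoning. For compound 4 the estimated value is 500 nM with an expected range from 150 nM to 1600 nM in that assay.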

Compound 4, half-maximal inhibitory concentration: 450 nM
For compound 4 the middle estimate is 1.1-fold (0.05 log units) above the measured one; the range from low to high includes it.
By their numbers in this assay, from the lowest: compound 2; then compound 4; then compound 1; then compound 3.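

In this assay, the benzyl ring needs no chlorine to outperform hydrogen on the aromatic nitrogen, as shown by a 7.0-fold lower number from compound 3 to compound 4 (0.84 log units; beyond the scatter). Compound 4 also gives chlorine a baseline, and the effect of adding it turns out to depend on the pattern: removing the chloro from the 3-chlorophenyl group gives a 2.0-fold higher number from compound 2 to compound 4 (0.31 log units; beyond the scatter), whereas replacing 2,4-dichlorophenyl with phenyl gives a 2.4-fold lower number from compound 1 to compound 4 (0.38 log units; beyond the scatter), so one chlorinated compound sits below the plain benzyl compound and the other above it. No measurement shown here explains why these chlorine patterns pull in opposite directions.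

The compounds shown leave open whether the aromatic ring itself is needed, which a methyl group or a longer alkyl chain on the same nitrogen could help to test. They also leave open whether the lower number seen with 3-chlorobenzyl is particular to chlorine or would also appear with a fluoro, methoxy or nitrile group on the benzyl ring.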